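Dropping a Fluorine from the Distal Phenyl Ring

The source may report more compounds than this note shows. Statements on the series, on what has been measured and on what is new or still open speak of the compounds shown alone.

Measured compounds:
compound 1 `O=C(CC1c2ccccc2N=C(SCCCCCN2CCCC2)N1c1ccc(-c2ccccc2)cc1)NCc1ccc(F)cc1` – 276000 nM
compound 2 `CN(C)CCCCCSC1=Nc2ccccc2C(CC(=O)NCc2ccccc2)N1c1ccc(-c2ccccc2)cc1` – 2400 nM
compound 3 `O=C(CC1c2ccccc2N=C(SCCCCCN2CCCC2)N1c1ccc(-c2ccc(F)cc2)cc1)NCc1ccccc1` – 260 nM

All three share one core and were tested in an assay on cells for inhibition of Voltage-dependent T-type calcium channel subunit alpha-1H (Homo sapiens), read by patch clamp; on this read-out higher numbers stand for weaker inhibition and lower numbers for stronger inhibition. Compound 3 gives the lowest number of the three; compound 2 gives a higher number, and compound 1 a far higher one, both gaps beyond the usual scatter of this assay, so compound 3 is the most potent measured member. Compound 4 `O=C(CC1c2ccccc2N=C(SCCCCCN2CCCC2)N1c1ccc(-c2ccccc2)cc1)NCc1ccccc1` has not been measured. It differs from compound 3 in one place only: hydrogen in place of fluoro on an aromatic carbon, or, seen one bond further out, 4-fluorophenyl becomes phenyl. For the measured compounds named here, no two measured compounds differ in just this one place, so no measured step shows what this change does here. The step is expected to be small, and compound 4 is expected to lie a 1.9-fold higher number from compound 3 to compound 4 (0.28 log units; within the scatter) from compound 3, tending a little toward weaker inhibition but possibly not beyond the scatter. Compound 4 is estimated at 500 nM, with a likely range from 150 nM to 2500 nM.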

Compound 4, half-maximal inhibitory concentration: 6900 nM
For compound 4 the middle estimate is 14-fold (1.14 log units) below the measured one, and the stated range ends below it.
By their numbers in this assay, from the lowest: compound 3; then compound 2; then compound 4; then compound 1.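

In compound 3 the fluoro, para to a large group, carries much of the potency: putting hydrogen in its place gives a 27-fold higher number from compound 3 to compound 4 (1.42 log units; beyond the scatter), a large loss of inhibition. The same swap on a different aromatic ring runs the opposite way, with a 40-fold lower number from compound 1 to compound 4 (1.60 log units; beyond the scatter), so in these two pairs removing a fluoro weakens or strengthens inhibition depending on which ring held it. With neither ring fluorinated, the amine at the chain end still counts, since pyrrolidin-1-yl in place of dimethylamino gives a 2.9-fold higher number from compound 2 to compound 4 (0.46 log units; beyond the scatter), a modest step. As far as these compounds go, whether a chlorine or a methyl group on this same aromatic carbon would keep the potency of compound 3 remains open. Nothing measured here says why this single atom matters so much.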